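The source may report more compounds than this note shows. Statements on the series, on what has been measured and on what is new or still open speak of the compounds shown alone.

Series notes. Among the compounds with values here, compound 1 `Cc1oc(-c2ccccc2Cl)nc1CN1CCC(C(=O)NCCCN2C[C@H](C)C[C@H](C)C2)CC1` is the only member with a number in an ADME assay on microsomes from liver (Rattus norvegicus) for metabolic stability, read by LC-MS, using NADPH, at 37 degrees C; on this read-out lower numbers stand for a shorter-lived compound and higher numbers for a longer-lived compound: compound 1 gives 0.25 h. Compound 2 `Cc1ccccc1-c1nc(CN2CCC(C(=O)NCCCN3CCC(C)CC3)CC2)c(C)o1` reports only a limit of the assay, > 0.5 h. Compound 3 `Cc1ccccc1-c1nc(CN2CCC(C(=O)N3CCN(C4CCN(C)CC4)CC3)CC2)c(C)o1` likewise reports a limit, > 0.5 h. Compound 1 thus stands at the low end of what is shown, the other two values being (the limit of > 0.5 h in this assay, at which 2 of the 3 values shown sit). Compound 4 `Cc1cc(C)cc(-c2nc(CN3CCC(C(=O)NCCCN4C[C@H](C)C[C@H](C)C4)CC3)c(C)o2)c1` carries 3,5-dimethylphenyl in place of 2-chlorophenyl on an aromatic carbon. Within the data shown here, no step between measured compounds in this assay is available to scale this change, and the values of compound 2 and compound 3 are limits, so they give no size to compare with. The step from compound 1 to compound 4 is expected to be small, a 1.4-fold higher number from compound 1 to compound 4 (0.15 log units; within the scatter), not clearly beyond the scatter. Compound 4 is estimated at 0.35 h, within 0.15 h to 0.9 h.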

Compound 4, half-life: < 0.5 h
Compound 4: only a limit was reported (the forecaster's own chance of this, stated with the estimate: 35%); the middle value is on the limit's open side.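

In this assay compound 4 reports < 0.5 h which is a limit of the assay, so the step from compound 1 to compound 4 cannot be read. On these data alone, whether 3,5-dimethylphenyl in place of 2-chlorophenyl shifts the half-life at all, and in which direction, stays open.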